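The source may hold more compounds than are shown below. What is called first, only, known or untested is meant among the compounds shown, and "the series" means these compounds.

Series notes. Compound 1 `O=C(Nc1ccc(Oc2ccnc3[nH]ccc23)cc1)c1cc2cccnc2n(-c2ccc(Br)cc2)c1=O` has no reported result in a functional assay on U-87MG ATCC cells for antiproliferative activity against U-87 MG (Homo sapiens), read by MTT assay, with a stated time of 72 h; on this read-out higher numbers stand for weaker inhibition and lower numbers for stronger inhibition: there compound 1 stands as "not determined" (no result reported). Among the measured compounds shown here, compound 2 `O=C(Nc1ccc(Oc2ccnc3[nH]ccc23)c(F)c1)c1cc2cccnc2n(-c2ccc(F)cc2)c1=O` is the one member with a number: in this assay compound 2 gives 620 nM. Compound 3 `O=C(Nc1ccc(Oc2ccnc3[nH]ccc23)c(F)c1)c1cc2cccnc2n(-c2ccc(Cl)cc2)c1=O` likewise has no reported result in this assay, where compound 3 stands as "not determined" (no result reported), so compound 3 stands without a number of its own, alongside one further entry that also lacks one; the only measured point in the set is compound 2. Compound 4 `O=C(Nc1ccc(Oc2ccnc3[nH]ccc23)c(F)c1)c1cc2cccnc2n(-c2ccc(Br)cc2)c1=O` differs from compound 3 by bromo in place of chloro on an aromatic carbon, or read one bond further out, 4-chlorophenyl to 4-bromophenyl. For the measured compounds named here, no measured pair in the set shares this change, so its size cannot be read from the data. The working expectation for this assay is a step of no more than the usual scatter, in no preferred direction, with compound 2 at 620 nM as the nearest measured neighbour, differing from compound 4 only in the halogen on that phenyl ring. Compound 4 is accordingly expected to give about 600 nM in this assay, with the estimate ranging from 200 nM to 2000 nM.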

Compound 4, half-maximal inhibitory concentration: 1510 nM
Estimate against measurement, compound 4: 2.5-fold (0.40 log units) below, and the stated range covers the measured number.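

Series notes, continued. In this assay, among the compounds shown here, the para halogen on the 4-substituted phenyl ring proves not to be a silent position: bromo in place of fluoro gives a 2.4-fold higher number from compound 2 to compound 4 (0.39 log units; beyond the scatter) and so moves the read-out towards weaker inhibition, the first change at this carbon that can be sized from the data. This is a single step between two halogens, and with compound 3 lacking a number, it gives two points rather than a trend across fluoro, chloro and bromo. Nothing measured on these compounds bears on why the number rises with this exchange.

Steps involving compound 1 or compound 3 cannot be read, so the place of chloro relative to fluoro and bromo remains unknown, as does any contribution from the fluoro on the ring carrying the ether link, which compound 1 lacks. The compounds shown also leave open how this carbon responds to groups other than halogens, such as a methoxy group, an amine or a carboxylic acid, and whether any replacement gives a lower number than the fluoro of compound 2.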